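The source may report more compounds than this note shows. Statements on the series, on what has been measured and on what is new or still open speak of the compounds shown alone.

Measured compounds:
Compound 1 `COc1cc(-c2cc(/C=C/C(=O)c3ccc(N)cc3)[nH]n2)cc(OC)c1OC` gives 1500 nM in a functional assay on MCF7 cells (Homo sapiens) for inhibition, read by sulforhodamine B assay, with a stated time of 48 h; a lower number here means a stronger inhibitor of growth, a higher number a weaker inhibitor of growth.
Compound 2 `COc1ccc(C(=O)/C=C/c2cc(-c3cc(OC)c(OC)c(OC)c3)n[nH]2)cc1` gives 1150 nM in this assay.

Going by the values given here, compound 2 stands beside compound 1 as one of only two measured numbers; the step of a 1.3-fold lower number from compound 1 to compound 2 (0.12 log units; within the scatter) lies within the scatter, so the two cannot be told apart on these data. Compound 3 `COc1cc(-c2cc(/C=C/C(=O)c3ccc(F)c(F)c3)[nH]n2)cc(OC)c1OC` differs from compound 2 by 3,4-difluorophenyl in place of 4-methoxyphenyl on a carbonyl carbon. Among the compounds with values here, no measured step bears directly on this change: the single step recorded, a 1.3-fold lower number from compound 1 to compound 2 (0.12 log units; within the scatter), swaps a group on an aromatic carbon and stays within the scatter, and no measured pair replaces a 4-methoxyphenyl with a 3,4-difluorophenyl. With both known numbers close together and no evidence that a change on this ring moves the value, the expected step of a 1.0-fold higher number from compound 2 to compound 3 (0.02 log units; within the scatter) is estimated to remain within the scatter. Compound 3 is therefore expected to give about 1200 nM, with a range from 400 nM to 3600 nM.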

Compound 3, concentration for 50% growth inhibition: 3200 nM
Compound 3: the middle estimate sits 2.7-fold (0.43 log units) below what was measured; low and high end bracket the measured number.
By their numbers in this assay, from the lowest: compounds 2 and 1 (each within the scatter of the next); then compound 3.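

In this assay the group on the carbonyl carbon proves able to move the number: 3,4-difluorophenyl in place of 4-methoxyphenyl gives a 2.8-fold higher number from compound 2 to compound 3 (0.44 log units; beyond the scatter) and in place of 4-aminophenyl gives a 2.1-fold higher number from compound 1 to compound 3 (0.33 log units; beyond the scatter) on the same core. Going by these compounds alone, the earlier amino-to-methoxy swap stayed within the scatter, so these are the first steps to pass beyond it, both modest and both towards weaker growth inhibition. Nothing available explains this shift.

The compounds shown leave open whether a plain phenyl, a 4-fluorophenyl or a 4-chlorophenyl on this carbonyl carbon would fall with compound 3 or stay with compounds 1 and 2. They also leave open whether a hydroxyl or a dimethylamino group on this ring would give a lower number than any seen so far.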